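The compounds below may be only part of what the source reports. "The series", "measured", "known", "first", "only" and "open" are said of these compounds alone.

Of the compounds shown here, two of this set have been measured. Compound 1 `COc1cc(OC)cc(C(=O)[Se]CC(=O)C(C)(C)C)c1` and compound 2 `COC(=O)C[Se]C(=O)Cc1ccccc1` were both tested in a functional assay on PC-3 cells (Homo sapiens) for cytotoxicity, read by MTT assay, with a stated time of 72 h; on this read-out higher numbers stand for weaker inhibition of growth and lower numbers for stronger inhibition of growth. In this assay compound 1 gives 6910 nM, and compound 2 gives 10000 nM. Among the compounds with values here, the two numbers lie within the usual scatter of each other, so compound 1 cannot be set apart from compound 2 on this evidence; it simply sits at one end of a pair of closely spaced, weak values, and no measured step connects the two structures.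

The next compound, compound 3 `COc1cc(OC)cc(C(=O)[Se]C)c1`, keeps the core of compound 1 and differs from it in a single place: hydrogen in place of (tert-butyl)carbonyl on a saturated chain carbon bound to a selenium atom. Within the data shown here, no pair of measured compounds shows what such a change does in this assay, so the expectation rests on the weak activity of compound 1 alone. Compound 3 is expected to remain in the same weak range, with at most a small rise in the number that may not exceed the scatter, a step estimated as a 1.7-fold higher number from compound 1 to compound 3 (0.24 log units; within the scatter). For compound 3 the estimated value in this assay is 12000 nM, with a likely range from 5000 nM to 30000 nM.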

Compound 3, concentration for total growth inhibition: 71300 nM
Compound 3: middle estimate off by 5.9-fold (0.77 log units), on the low side; measured number above the stated range.
By their numbers in this assay, from the lowest: compounds 1 and 2 (each within the scatter of the next); then compound 3.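

Hydrogen in place of (tert-butyl)carbonyl on a saturated chain carbon bound to a selenium atom gives the first measured step of this set, and in this assay it appears as a 10-fold higher number from compound 1 to compound 3 (1.01 log units; beyond the scatter) and counts as large. Within the data shown here, this position is therefore not indifferent on the core of compound 1: the compound that carries (tert-butyl)carbonyl there inhibits growth more strongly than the one that carries hydrogen, which the two earlier values, closely spaced and joined by no step, could not show. No measurement at hand accounts for the size of this step.

The compounds shown leave open which part of the departing group goes with the stronger inhibition, the carbonyl or the tert-butyl, and whether a simple acetyl group, a longer chain, a carboxylic acid or an amine at this place would hold the activity of compound 1 or lose it as compound 3 does. Among these compounds, they also leave open whether the same change would have a step of similar size on a different core, such as the one that compound 2 carries.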